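This account rests on a few compounds, and the source may have more. Where it says the series, first, only, none or still open, it means among the compounds named here.

Going by the values given here, compound 2 (`CC/N=C(\S)NCCCn1nc(-c2ccccc2)ccc1=O`) is one of only two compounds that have been tested in a functional assay on the whole organism (stomach) with Rattus norvegicus as the target; on this read-out lower numbers stand for an effect already at smaller amounts and higher numbers for an effect only at larger amounts of compound. In this assay compound 2 gives > 100 mg/kg, which is a limit of the measurement rather than a number. Compound 1 (`CC(C)(C)/N=C(\S)NCCCCn1nc(-c2ccccc2)ccc1=O`) is the other tested compound, and in this assay compound 1 gives > 100 mg/kg, again a limit. Among the compounds with values here, compound 2 therefore stands exactly where every measured value stands, because of the limit of > 100 mg/kg in this assay, at which 2 of the 2 values shown sit; the two values show no separation between compound 2 and compound 1, only that neither produced a number.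

Compound 3 (`C/N=C(\NC#N)NCCCCn1nc(-c2ccccc2)ccc1=O`) has not yet been tested in this assay. It differs from compound 2 by a group of 8 heavy atoms (4 carbon, 4 nitrogen; no ring) in place of a group of 6 heavy atoms (3 carbon, 2 nitrogen, 1 sulfur; no ring), on a saturated chain carbon, three bonds along the chain from an aromatic nitrogen. Within the data shown here, no step between two measured compounds exists to set the size of such a change, and the two values at hand are both limits. The step from compound 2 to compound 3 is therefore expected to stay within the scatter, a number no higher from compound 2 to compound 3 (the limit leaves the size open), with no direction indicated. Compound 3 is expected to give 100 mg/kg in this assay, within a range from 30 mg/kg to 300 mg/kg, and most probably again only a limit.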

Compound 3, dose for half-maximal effect: 32.4 mg/kg
Beside the measured number, compound 3's estimate is 3.1-fold (0.49 log units) above it, within the range that was stated.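

With compound 3, this assay gives the only number among the compounds shown, so the place on a saturated chain carbon, three bonds along the chain from an aromatic nitrogen, now proves open to a change that can be read. There, a group of 8 heavy atoms (4 carbon, 4 nitrogen; no ring) in place of a group of 6 heavy atoms (3 carbon, 2 nitrogen, 1 sulfur; no ring) gives an at least 3.0-fold lower number from compound 2 to compound 3 (0.48 log units; beyond the scatter), and on an amine nitrogen, a different exchange of groups gives an at least 3.0-fold lower number from compound 1 to compound 3 (0.48 log units; beyond the scatter) as the second step. Both steps fix only the smallest size the change can have, because each starts from a limit: the limit of > 100 mg/kg in this assay, at which 2 of the 3 values shown sit.

The compounds shown leave open whether the nitrile itself carries the step or the rest of the entering group does. They also leave open how the read-out would move with a plain amine, a carboxylic acid or a longer chain at this place.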